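Trading trifluoromethyl for acetyl in a low-toxicity series

The source may report more compounds than this note shows. Statements on the series, on what has been measured and on what is new or still open speak of the compounds shown alone.

Measured in an ADME assay on MT4 cells (Homo sapiens) for cytotoxicity, read by MTT assay, with a stated time of 96 h; on this read-out higher numbers stand for lower toxicity in this test and lower numbers for higher toxicity in this test:
- Compound 1 `O=[N+]([O-])c1ccc(-c2nc3ccccc3[nH]2)c([N+](=O)[O-])c1` gives 7000 nM
- Compound 2 `COc1ccc(-c2nc3cc(C(F)(F)F)ccc3[nH]2)c(OC)c1` gives > 100000 nM (a limit of the assay)
- Compound 3 `COc1ccc(-c2nc3cc(C(F)(F)F)ccc3[nH]2)c(OC)c1OC` gives 93000 nM

Of the two exact numbers, compound 3 at 93000 nM stands highest, and compound 1 at 7000 nM lies lower, a gap beyond the scatter. Compound 2 returned only a limit, > 100000 nM, so its true position is not known.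

The next compound to be tested is compound 4 `COc1ccc(-c2nc3cc(C(C)=O)ccc3[nH]2)c(OC)c1OC`, which has not yet been measured. Its structure departs from compound 3 by acetyl in place of trifluoromethyl on an aromatic carbon.

For the measured compounds named here, only one measured step is available, an at least 1.0-fold lower number from compound 2 to compound 3 (0.03 log units; that floor lies within the scatter), and it lies within the scatter. That step places methoxy in place of hydrogen, a different change, so it bears on the present one only indirectly. Going by the values given here, no measured pair exchanges trifluoromethyl for acetyl. In this assay, a modest move towards a lower number is therefore expected, estimated as a 1.6-fold lower number from compound 3 to compound 4 (0.19 log units; within the scatter), and no step beyond the scatter is anticipated.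

The estimated value for compound 4 is 60000 nM, with an expected range from 20000 nM to 100000 nM.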

Compound 4, half-maximal cytotoxic concentration: > 100000 nM
Compound 4 ended at the assay's limit; the forecaster's own chance of this, stated with the estimate: 35%; at least 1.6-fold (0.22 log units) between middle value and limit.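

For the compounds shown here, putting acetyl in place of trifluoromethyl on this aromatic carbon gives an at least 1.0-fold higher number from compound 3 to compound 4 (0.03 log units; that floor lies within the scatter) in this assay, and this is the first measured change at this place, since compound 2 and compound 3 both carry trifluoromethyl there and differ only by a methoxy group elsewhere. Compound 4 gives > 100000 nM, which is a limit of the assay and not a number. The result shows that, with the three methoxy groups of compound 3 held fixed, trifluoromethyl is not needed for the read-out to stay at the low-toxicity end of this test, and that acetyl brings no sign of a move towards lower numbers, though the size of any move cannot be read at the top of the range: the limit of > 100000 nM in this assay, at which 2 of the 4 values shown sit.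

Going by these compounds, how far compound 4 truly lies from compound 3 stays open, as does whether acetyl would behave the same way on the dimethoxy pattern of compound 2. Equally open, on these data alone, is what other groups on this aromatic carbon would do, such as an amine, a carboxylic acid or a longer chain.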